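Methyl to Methoxy on Two Thiazolidinone Cores

The source may hold more compounds than are shown below. What is called first, only, known or untested is meant among the compounds shown, and "the series" means these compounds.

Measured compounds in a functional assay on MCF7 cells (Homo sapiens) for cytotoxicity, read by MTT assay, with a stated time of 72 h; on this read-out higher numbers stand for weaker inhibition and lower numbers for stronger inhibition:
Compound 1 `Cc1ccc(-c2cc(/N=C3/NC(=O)CS3)cs2)cc1` gives > 50000 nM, which is a limit of the assay and not a number.
Compound 2 `COc1ccc(-c2cc(/N=C3/NC(=O)CS3)cs2)cc1` gives > 50000 nM, again a limit rather than a number.
Compound 3 `Cc1ccc(/C=C2\S/C(=N\c3nc(-c4ccc(Cl)cc4)cs3)NC2=O)cc1` gives 400 nM.

Compound 1 and compound 2 differ by methoxy in place of methyl on an aromatic carbon, and the step between them is a step that the two limits leave unreadable from compound 1 to compound 2; the values sit at the limit of > 50000 nM in this assay, at which 2 of the 3 values shown sit. The difference between the core of compound 1 and the core of compound 3 is not broken down here. Compound 4 `COc1ccc(/C=C2\S/C(=N\c3nc(-c4ccc(Cl)cc4)cs3)NC2=O)cc1`, not yet measured, differs from compound 3 by methoxy in place of methyl on an aromatic carbon, the same change, at the same place, as from compound 1 to compound 2.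

Since that step left no readable size, the expectation for compound 4 rests on compound 3 alone, whose value is 400 nM. Compound 4 is expected to show a step of a 1.3-fold higher number from compound 3 to compound 4 (0.10 log units; within the scatter), within the usual scatter. The estimate for compound 4 is 500 nM, between 150 nM and 2000 nM.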

Compound 4, half-maximal inhibitory concentration: 100 nM
Beside the measured number, compound 4's estimate is 5.0-fold (0.70 log units) above it; measured number below the stated range.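

In this assay, placing methoxy where compound 3 has methyl gives a 4.0-fold lower number from compound 3 to compound 4 (0.60 log units; beyond the scatter), a modest step that lies beyond the usual scatter. The same change on the other core cannot be read, since compound 1 and compound 2 both sit at a limit of the assay and not at a number: the limit of > 50000 nM in this assay, at which 2 of the 4 values shown sit.

Within the data shown here, only one readable step therefore exists, on one core, and it shows neither that the effect of this change carries from one core to another nor that it fails to. The compounds shown leave open how an amine, a carboxylic acid or a longer chain such as ethoxy would compare at the same place on the core of compound 3.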